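Working notes: methylation of the sulfanyl group in compound 3

A few compounds are considered here, and "the series" means these few. Any claim that something is new, unique, unknown or untested is made for them only; others in the source may bear on it.

Compound 1, `CC(C)(C)c1ccnc(Cl)n1`, in a functional assay on the whole organism for inhibition, with Rattus norvegicus as the target, with stated times of 1 h and 3.5 h, at a dose of 100 mg/kg by the oral route (on this read-out lower numbers stand for less inhibition and higher numbers for more inhibition at the one dose given (going by the name of the read-out)), gives < 5%, which is a limit of the assay.
Compound 2, `CN(C)c1nccc(C(C)(C)C)n1`, in this assay gives 18%.
Compound 3, `CC(C)(C)c1ccnc(S)n1`, in this assay gives 22%.

Compound 3 holds the higher of the two actual numbers, but its nearest neighbour is compound 2, and the step of a number 4 percentage points higher from compound 2 to compound 3 (within the scatter) does not separate them. Both steps away from compound 1 are larger: a number at least 13 percentage points higher from compound 1 to compound 2 (beyond the scatter) and a number at least 17 percentage points higher from compound 1 to compound 3 (beyond the scatter), each beyond the scatter, though the starting point is only a limit (the limit of < 5% in this assay, at which 1 of the 3 values shown sits).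

Compound 4, `CSc1nccc(C(C)(C)C)n1`, is not yet measured. It differs from compound 3 by methyl in place of hydrogen on a sulfur.

Among the compounds with values here, none of the measured steps touches the sulfur itself; all three swap a group on an aromatic carbon, so they speak to compound 4 only by showing that the sulfanyl and dimethylamino variants sit within the scatter of each other. Adding a methyl on the sulfur is a smaller change than any of those. In this assay compound 4 is therefore expected to stay near compound 3, with a step of a number 2 percentage points lower from compound 3 to compound 4 (within the scatter) that is not expected to exceed the scatter. The estimate for compound 4 is 20%, with a range from 5% to 40%.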

Compound 4, a percentage reported as inhibition, in the whole organism at one dose (the size of the read-out at that dose, not a potency): 35%
Compound 4: middle estimate off by 15 percentage points, on the low side; measured number inside the range.
By their numbers in this assay, from the lowest: compounds 2 and 3 (each within the scatter of the next); then compound 4. At a limit, below all of these: compound 1.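

Methyl on the sulfur gives a number 13 percentage points higher from compound 3 to compound 4 (beyond the scatter) in this assay. Within the data shown here, this is the first measured step at the sulfur itself, and it shows that the read-out responds to a change as small as sulfanyl to methylsulfanyl. On the aromatic carbon, sulfanyl and dimethylamino could not be separated, whereas methylsulfanyl can be separated from dimethylamino, with a number 17 percentage points higher from compound 2 to compound 4 (beyond the scatter). Against chloro the result is a number at least 30 percentage points higher from compound 1 to compound 4 (beyond the scatter), and that step starts from a limit: the limit of < 5% in this assay, at which 1 of the 4 values shown sits.

With methyl as the only group shown on the sulfur, it stays open whether a longer chain such as ethyl or propyl, or a chain ending in an amine or a carboxylic acid, would raise or lower the read-out further. All four compounds share the same core and each was read at a single oral dose, so the compounds shown say nothing about potency or about whether the step from sulfanyl to methylsulfanyl carries over to another core.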